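The source may hold more compounds than are shown below. What is called first, only, known or untested is meant among the compounds shown, and "the series" means these compounds.

Compound 3 `Cc1c(OCCCCOc2ccc(C(=O)O)cc2)ccc(C(=O)CC(C)C)c1C` carries an isobutyl ketone on the shared core; in an assay on HEK293 cells for positive allosteric modulation of metabotropic glutamate receptor 2 (Rattus norvegicus), read by thallium flux, with a stated time of 2.5 min (a lower number here means that less compound is needed, a higher number that more compound is needed for the effect), compound 3 gives "not determined" (no result reported), so no number stands against its name. The same holds for compound 2 `Cc1c(OCCCCOc2ccc(C(=O)O)cc2)ccc(C(=O)CC2CCCC2)c1C`, which in this assay gives "not determined" (no result reported). Among the measured compounds shown here, the only number in the set belongs to compound 1 `Cc1c(OCCCCOCOc2ccc(C(=O)O)cc2)ccc(C(=O)CC2CCCC2)c1O`, which differs from the others in several places and in this assay gives 228 nM. Compound 4 `Cc1c(OCCCCOc2cccc(C(=O)O)c2)ccc(C(=O)CC(C)C)c1C` is reached from compound 3 by one change: 3-carboxyphenyl in place of 4-carboxyphenyl on an oxygen on a saturated carbon. For the measured compounds named here, no measured step of this kind exists here, so the size and direction of its effect cannot be read from the data. Going by the values given here, on the single number available, compound 4 is estimated at 600 nM, with a range from 100 nM to 4000 nM.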

Compound 4, half-maximal effective concentration: "not active" (no number reported)
For compound 4 the study gives words and no number, so the estimate cannot be set against anything.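

In this assay neither compound 3 nor compound 4 has a number, so no step can be read between them. Nothing shown bears on this result. The compounds shown leave open what 3-carboxyphenyl in place of 4-carboxyphenyl does to the effect.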